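This account rests on a few compounds, and the source may have more. Where it says the series, first, only, none or still open, it means among the compounds named here.

Two compounds have been measured in an ADME assay on MCF-10A cells (Homo sapiens) for cytotoxicity, read by MTT assay, with a stated time of 48 h; a lower number here means a stronger inhibitor, a higher number a weaker inhibitor:

Compound 1, `COc1cc2cc(C(=O)NCCCc3ccc(F)cc3)c(=O)oc2cc1OCCCOc1no[n+]([O-])c1S(=O)(=O)c1ccccc1`: 8920 nM
Compound 2, `COc1ccc(CNC(=O)c2cc3cc(OC)c(OCCCOc4no[n+]([O-])c4S(=O)(=O)c4ccccc4)cc3oc2=O)cc1`: 5950 nM

Among the measured compounds shown here, compound 2 stands at the lowest of these two numbers, with compound 1 nearest, and the one measured step, a 1.5-fold lower number from compound 1 to compound 2 (0.18 log units; within the scatter), lies within the scatter. Compound 3, `COc1cc2cc(C(=O)Nc3ccc(F)cc3)c(=O)oc2cc1OCCCOc1no[n+]([O-])c1S(=O)(=O)c1ccccc1`, differs from compound 2 in that (4-fluorophenyl in place of 4-methoxybenzyl on an amide-type nitrogen). For the measured compounds named here, the only step that bears on this sits on the same amide-type nitrogen and stayed within the scatter, so no step beyond the scatter is expected in this assay. Compound 3 is therefore estimated at 7000 nM, in the range 3000 nM to 16000 nM, an expected step of a 1.2-fold higher number from compound 2 to compound 3 (0.07 log units; within the scatter).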

Compound 3, half-maximal inhibitory concentration: 7210 nM
The estimate for compound 3 lay 1.0-fold (0.01 log units) below the measured number; the range from low to high includes it.
By their numbers in this assay, from the lowest: compounds 2, 3 and 1 (each within the scatter of the next).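

In this assay the change to 4-fluorophenyl from 4-methoxybenzyl on the amide-type nitrogen gives a 1.2-fold higher number from compound 2 to compound 3 (0.08 log units; within the scatter) and leaves the reading within the usual spread, and the change to 4-fluorophenyl from 3-(4-fluorophenyl)propyl gives a 1.2-fold lower number from compound 1 to compound 3 (0.09 log units; within the scatter) with the same outcome. This position has therefore carried an aromatic ring bound directly to the nitrogen or held out on a chain, with no step beyond the scatter among these three compounds. Nothing available explains this result. On these data alone, whether an amine or a carboxylic acid on this nitrogen would give a step beyond the scatter remains open. So does the effect of changing anything elsewhere in the molecule, such as the phenylsulfonyl group.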